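This account rests on a few compounds, and the source may have more. Where it says the series, first, only, none or still open, it means among the compounds named here.

Measured so far:
compound 1, `N#C/C(=C\c1cc(O)c(O)c([N+](=O)[O-])c1)C(=O)N(c1ccccc1)c1ccccc1`: 56.2 ug/mL
compound 2, `N#C/C(=C\c1cc(O)c(O)c([N+](=O)[O-])c1)C(=O)Nc1cccc(Cl)c1`: 40.1 ug/mL

Both numbers come from a functional assay on Bel-7402 cells (Homo sapiens) for antiproliferative activity, read by MTT assay; on this read-out lower numbers stand for stronger inhibition and higher numbers for weaker inhibition. Compound 2 shows the lower of the two numbers, but compound 1 sits close, within the scatter, so the two are not told apart. Compound 3, `N#C/C(=C\c1cc(O)c(O)c([N+](=O)[O-])c1)C(=O)N1CCOCC1`, is not yet measured. The change is morpholin-4-yl in place of (3-chlorophenyl)amino on a carbonyl carbon. Among the measured compounds shown here, no measured pair carries this change, so its size is unknown from the series. A step of uncertain direction, not clearly beyond the scatter, is expected: a 1.4-fold higher number from compound 2 to compound 3 (0.14 log units; within the scatter). Compound 3 is expected near 55 ug/mL, within a range from 22 ug/mL to 130 ug/mL.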

Compound 3, half-maximal inhibitory concentration: > 100 ug/mL
Compound 3: only a limit was reported; the forecaster's own chance of this, stated with the estimate: 15%; at least 1.8-fold (0.25 log units) between middle value and limit.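

In this assay compound 3 gives only a limit, > 100 ug/mL, not a number. Morpholin-4-yl in place of (3-chlorophenyl)amino on a carbonyl carbon gives an at least 2.4-fold higher number from compound 2 to compound 3 (0.39 log units; beyond the scatter), so this position now shows a step beyond the scatter, which the earlier pair of values did not show. That step has a lower bound only, and its full size stays unknown: the limit of > 100 ug/mL in this assay, at which 1 of the 3 values shown sits.

The compounds shown do not separate the loss of the aromatic ring from the entry of the ring oxygen. A piperidin-1-yl group on the same carbonyl carbon would address that question.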